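Estimating Compound 4 from Two Measured Changes

The source may hold more compounds than are shown below. What is called first, only, known or untested is meant among the compounds shown, and "the series" means these compounds.

Compound 1 `COc1cc(C(=O)c2cn(-c3ccccc3)cc2-c2cccc([N+](=O)[O-])c2)cc(OC)c1OC` is the starting point of this small set. In a functional assay on MCF7 cells (Homo sapiens) for cytotoxicity, read by MTT assay, with a stated time of 96 h (on this read-out higher numbers stand for weaker inhibition and lower numbers for stronger inhibition), compound 1 gives 50 nM. Compound 2 `COc1cc(C(=O)c2cn(-c3ccccc3)cc2-c2ccc([N+](=O)[O-])cc2)cc(OC)c1OC` differs from it by 4-nitrophenyl in place of 3-nitrophenyl on an aromatic carbon, and in this assay compound 2 gives 590 nM, a move that amounts to a 12-fold higher number from compound 1 to compound 2 (1.07 log units; beyond the scatter). Compound 3 `COc1cc(C(=O)c2cn(-c3cccc(N)c3)cc2-c2cccc([N+](=O)[O-])c2)cc(OC)c1OC` differs from compound 1 by amino in place of hydrogen on an aromatic carbon; in this assay compound 3 gives 510 nM, which is a 10-fold higher number from compound 1 to compound 3 (1.01 log units; beyond the scatter). Compound 4 `COc1cc(C(=O)c2cn(-c3cccc(N)c3)cc2-c2ccc([N+](=O)[O-])cc2)cc(OC)c1OC` has not yet been measured. It differs from compound 3 by 4-nitrophenyl in place of 3-nitrophenyl on an aromatic carbon. Among the measured compounds shown here, this is the same kind of change as the one from compound 1 to compound 2, though the surroundings are not identical: in the earlier pair the place lies two ring bonds from the ring atom that bears a phenyl group, whereas here it lies two ring bonds from the ring atom that bears a 3-aminophenyl group. If the change behaves as it did before, the step from compound 3 to compound 4 is expected to be about an 8.8-fold higher number from compound 3 to compound 4 (0.95 log units; beyond the scatter). On that basis compound 4 is expected to give roughly 4500 nM in this assay, with a likely range from 1300 nM to 15000 nM. The estimate rests on compound 3, whose value is 510 nM, and on the earlier step of a 12-fold higher number from compound 1 to compound 2 (1.07 log units; beyond the scatter).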

Compound 4, half-maximal inhibitory concentration: 110 nM
The estimate for compound 4 lay 41-fold (1.61 log units) above the measured number, outside the stated range (below it).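

In this assay, putting 4-nitrophenyl in place of 3-nitrophenyl on the core that carries the 3-aminophenyl group gives a 4.6-fold lower number from compound 3 to compound 4 (0.67 log units; beyond the scatter), so the same swap that raised the number on the core of compound 1 lowers it here: the same change on two cores in this assay, a 12-fold higher number (1.07 log units; beyond the scatter) from compound 1 to compound 2 and a 4.6-fold lower number (0.67 log units; beyond the scatter) from compound 3 to compound 4, 55-fold (1.74 log units) apart, beyond the scatter of two such steps

The amino group reverses in the same way, giving a 5.4-fold lower number from compound 2 to compound 4 (0.73 log units; beyond the scatter) when added to the 4-nitrophenyl compound, the opposite direction to its effect on compound 1: the same change on two cores in this assay, a 10-fold higher number (1.01 log units; beyond the scatter) from compound 1 to compound 3 and a 5.4-fold lower number (0.73 log units; beyond the scatter) from compound 2 to compound 4, 55-fold (1.74 log units) apart, beyond the scatter of two such steps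

Neither change can therefore be carried from one core to the other as a fixed step, since the effect of each depends on the other, but these four compounds in a single assay do not show why this happens or how far it extends through the series.

On these data alone, it remains open whether the reversal would also appear with a hydroxyl group in place of the amino group, or with a nitrile in place of the nitro group. Whether it would hold in other cell lines is also unknown.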